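The compounds below may be only part of what the source reports. "The series", "measured", "known", "first", "only" and "open" are said of these compounds alone.

Within the data shown here, compound 2, `CCOc1cc([C@](O)(CCN(C)C)[C@@H](c2cc3cc(Br)ccc3nc2OC)c2ccnc(OC)c2OC)cc(OC)n1`, gives 7.6 uL/min in an ADME assay on microsomes from liver (Mus musculus) for metabolic stability; on this read-out lower numbers stand for slow clearance and higher numbers for fast clearance; it stands lowest of the two numbers so far, with compound 1, `CCOc1cc([C@](O)(CCN(C)C)[C@H](c2cccc(C)c2)c2cc3cc(Br)ccc3nc2OC)cc(OC)n1`, nearest at 7.8 uL/min. Among the measured compounds shown here, the only measured step, a 1.0-fold lower number from compound 1 to compound 2 (0.01 log units; within the scatter), alters a different part of the molecule and lies within the scatter, so the series has so far been flat in this assay. Compound 3, `COc1cc([C@](O)(CCN(C)C)[C@@H](c2cc3cc(Br)ccc3nc2OC)c2ccnc(OC)c2OC)cc(OC2CCC2)n1`, differs from compound 2 by cyclobutyl in place of ethyl on an oxygen on an aromatic ring; the same difference, cut one bond further out, reads ethoxy to cyclobutyloxy. For the measured compounds named here, no measured step touches this oxygen on the aromatic ring, so there is no precedent for the size or direction of the change, and the flat behaviour of compound 1 and compound 2 is the only guide. The step of a 1.2-fold higher number from compound 2 to compound 3 (0.07 log units; within the scatter) is therefore expected to stay within the scatter, with no direction to predict, and the range is widened to allow for the lack of a precedent. Compound 3 is estimated at 9 uL/min, between 4 uL/min and 20 uL/min.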

Compound 3, intrinsic clearance in a liver preparation (reported as CLH), per the amount of preparation that the assay uses: 4.6 uL/min
Compound 3: middle estimate off by 2.0-fold (0.29 log units), on the high side; the range from low to high includes it.
By their numbers in this assay, from the lowest: compounds 3, 2 and 1 (each within the scatter of the next).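

Among these compounds, this is the first reading at the oxygen on an aromatic ring: in this assay, cyclobutyl in place of ethyl gives a 1.7-fold lower number from compound 2 to compound 3 (0.22 log units; within the scatter), so a four-membered non-aromatic ring of carbon only can stand at this place without a step beyond the scatter. With a 1.0-fold lower number from compound 1 to compound 2 (0.01 log units; within the scatter) at another place, both readable changes in the series remain within the scatter, and neither place has yet been shown to move this read-out. Nothing available here bears on the reason for the result.

Going by these compounds, whether another group on this oxygen, such as a longer chain, a cyclopropyl or a chain carrying an amine, would give a step beyond the scatter remains open. On these data alone, it is also open whether cyclobutyl in place of ethyl reads the same way on compound 1.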